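A few compounds are considered here, and "the series" means these few. Any claim that something is new, unique, unknown or untested is made for them only; others in the source may bear on it.

Measured so far:
Compound 1, `Cc1cccc(-c2noc([C@H](C)NC(=O)c3cc(C(F)(F)F)nn3C)n2)n1`, in an assay on T-REx-293 cells for inhibition of potassium channel subfamily T member 1 (Homo sapiens), read by patch clamp (a lower number here means a stronger inhibitor, a higher number a weaker inhibitor), gives > 30000 nM, which is a limit of the assay and not a number.
Compound 2, `C[C@H](NC(=O)c1cc(C(F)(F)F)nn1C)c1nc(-c2ccncc2)no1`, in this assay gives 5250 nM.
Compound 3, `COc1cc(-c2noc([C@H](C)NC(=O)c3cc(C(F)(F)F)nn3C)n2)cc(C)n1`, in this assay gives 505 nM.

Among the two numbers shown, compound 3 holds the lowest; its nearest neighbour is compound 2, and the step of a 10-fold lower number from compound 2 to compound 3 (1.02 log units; beyond the scatter) lies beyond the scatter. The third compound sits at a limit only (the limit of > 30000 nM in this assay, at which 1 of the 3 values shown sits).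

Compound 4, `CO[C@@H](C)c1cc(-c2noc([C@H](C)NC(=O)c3cc(C(F)(F)F)nn3C)n2)ccn1`, has not yet been measured. Its difference from compound 3 is a group of 10 heavy atoms (8 carbon, 1 nitrogen, 1 oxygen; one six-membered aromatic ring with 1 hetero atom) in place of a group of 9 heavy atoms (7 carbon, 1 nitrogen, 1 oxygen; one six-membered aromatic ring with 1 hetero atom), on an aromatic carbon. The group that leaves and the group that enters are both six-membered aromatic rings with one hetero atom, and the count of hydrogen-bond acceptors does not change.

Going by the values given here, two measured steps bear on this exchange of one such ring for another: an at least 5.7-fold lower number from compound 1 to compound 2 (0.75 log units; beyond the scatter) and a 10-fold lower number from compound 2 to compound 3 (1.02 log units; beyond the scatter), both large enough to stand beyond the scatter, and the combined step an at least 59-fold lower number from compound 1 to compound 3 (1.77 log units; beyond the scatter). These show that the choice of this ring moves the number substantially. Compound 4 keeps a substituted ring, as compound 3 does, but the substituent differs, so the expected step of a 1.8-fold higher number from compound 3 to compound 4 (0.25 log units; within the scatter) is modest and toward a higher number. Compound 4 is therefore expected to give about 900 nM, within a range from 250 nM to 3000 nM.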

Compound 4, half-maximal inhibitory concentration: 744 nM
Beside the measured number, compound 4's estimate is 1.2-fold (0.08 log units) above it, within the range that was stated.
By their numbers in this assay, from the lowest: compounds 3 and 4 (each within the scatter of the next); then compound 2. At a limit, above all of these: compound 1.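

Setting a 1-methoxyethyl group in place of hydrogen on the pyridin-4-yl ring gives a 7.1-fold lower number from compound 2 to compound 4 (0.85 log units; beyond the scatter), so a single substituent is enough here, where the earlier compounds showed a gain of this size only with the 2-methoxy-6-methylpyridin-4-yl ring. Against that ring, the new group gives a 1.5-fold higher number from compound 3 to compound 4 (0.17 log units; within the scatter), so the two substituted rings cannot be told apart in this assay. Compound 1 stands at a limit and not a number, so an at least 40-fold lower number from compound 1 to compound 4 (1.60 log units; beyond the scatter) gives only a minimum size for that step: the limit of > 30000 nM in this assay, at which 1 of the 4 values shown sits.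

As far as these compounds go, what the opposite arrangement at the stereocentre of the 1-methoxyethyl group would give stays open. Also open, from the compounds shown here alone, is how a plain ethyl group or a dimethylamino group in its place would compare, which would test whether the oxygen of the group matters.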